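The source may report more compounds than this note shows. Statements on the series, on what has been measured and on what is new or still open speak of the compounds shown alone.

Measured compounds:
compound 1 `C[C@H]1[C@H](NCc2ccc(C(C)(C)C)s2)C[C@H]2C[C@@H]1C2(C)C` — 780 nM in an ADME assay on MDCK cells (Canis lupus familiaris) for cytotoxicity, read by microscopy, with a stated time of 48 h; a lower number here means that less compound is tolerated, a higher number that more compound is tolerated
compound 2 `C[C@H]1[C@H](NCc2sccc2C2CCCCC2)C[C@H]2C[C@@H]1C2(C)C` — 1560 nM in this assay

Of the two numbers, compound 2 and compound 1 lie within the usual scatter of each other, so they cannot be told apart. Compound 3 `C[C@H]1[C@H](NCc2sccc2C2CC2)C[C@H]2C[C@@H]1C2(C)C` is not yet measured. It differs from compound 2 by cyclopropyl in place of cyclohexyl on an aromatic carbon. Among the measured compounds shown here, no measured pair shows this kind of change, so no size for it is known. In this assay the step from compound 2 to compound 3 is expected to stay within the scatter, a 1.3-fold lower number from compound 2 to compound 3 (0.11 log units; within the scatter). Compound 3 is therefore estimated at 1200 nM, with a range from 400 nM to 4000 nM.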

Compound 3, minimum cytotoxic concentration: 25000 nM
Compound 3: middle estimate off by 21-fold (1.32 log units), on the low side; the whole stated range lies below it.
By their numbers in this assay, from the lowest: compounds 1 and 2 (each within the scatter of the next); then compound 3.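

In this assay, the group on this aromatic carbon of the sulfur-containing ring clearly matters: cyclopropyl in place of cyclohexyl gives a 16-fold higher number from compound 2 to compound 3 (1.20 log units; beyond the scatter), so much more compound is tolerated. Compound 1 and compound 2 differ in more than one place, so they could not show the effect of a single change like this one. Nothing available explains the size of this step.

Going by these compounds, whether cyclobutyl or cyclopentyl at this carbon would give a number between those of compound 2 and compound 3 remains open. So does the outcome with a methyl or an amine there.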